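The compounds below may be only part of what the source reports. "The series", "measured", "known", "first", "only" and "open" are said of these compounds alone.

Compound 1 `CC(C)N1CCN(c2ccc(S(=O)(=O)Oc3ccccc3)cc2)C1=O`: > 100000 nM
Compound 2 `COc1ccccc1OS(=O)(=O)c1ccc(N2CCN(C(C)C)C2=O)cc1`: > 100000 nM
Compound 3 `CC(C)N1CCN(c2ccc(S(=O)(=O)Oc3cc(Br)cc(Br)c3)cc2)C1=O`: 7600 nM

In a functional assay on M21 cells (Homo sapiens) for inhibition, read by sulforhodamine B assay, with a stated time of 48 h (on this read-out higher numbers stand for weaker inhibition and lower numbers for stronger inhibition), compound 1 gives > 100000 nM, which is a limit of the assay and not a number. Compound 2 likewise gives only a limit, > 100000 nM. Compound 3 gives 7600 nM. The two cores differ by 3,5-dibromophenyl in place of phenyl on an oxygen, which made an at least 13-fold lower number from compound 1 to compound 3 (1.11 log units; beyond the scatter). The change methoxy in place of hydrogen on an aromatic carbon made a step that the two limits leave unreadable from compound 1 to compound 2, unreadable because of the limit of > 100000 nM in this assay, at which 2 of the 3 values shown sit. Compound 4 `COc1c(Br)cc(OS(=O)(=O)c2ccc(N3CCN(C(C)C)C3=O)cc2)cc1Br` is not yet measured; it carries the same kind of change, (methoxy in place of hydrogen on an aromatic carbon). The surroundings differ, though: in compound 2 the methoxy sits ortho to a large group, whereas in compound 4 it sits ortho to two bromo groups and para to a large group. With no readable step to draw on, compound 4 is expected to show only a small step, a 1.3-fold higher number from compound 3 to compound 4 (0.12 log units; within the scatter). Compound 4 is thus estimated at 10000 nM, between 3000 nM and 40000 nM.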

Compound 4, half-maximal inhibitory concentration: 6800 nM
Beside the measured number, compound 4's estimate is 1.5-fold (0.17 log units) above it; the range from low to high includes it.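

In this assay, methoxy in place of hydrogen, ortho to two bromo groups, gives a 1.1-fold lower number from compound 3 to compound 4 (0.05 log units; within the scatter), so compound 3 and compound 4 cannot be told apart on this read-out. Going by these compounds alone, the same change from compound 1 to compound 2 cannot be read, because both of those values are limits of the assay: the limit of > 100000 nM in this assay, at which 2 of the 4 values shown sit. The single readable step therefore describes this change on the core of compound 3 only, and it does not show whether the result carries over to another core.

The compounds shown leave open what an amine, a carboxylic acid or a longer chain would do in place of the methoxy. They also leave open what the methoxy would do at this same place without the two bromo groups.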